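Swapping Bromo for Cyano on the Sulfonyl Ring

The source may report more compounds than this note shows. Statements on the series, on what has been measured and on what is new or still open speak of the compounds shown alone.

Measured in a functional assay on QGY-7703 cells (Homo sapiens) for cytotoxicity, read by MTT assay, with a stated time of 24 h; on this read-out lower numbers stand for stronger inhibition and higher numbers for weaker inhibition:
- compound 1 `N#Cc1ccc(S(=O)(=O)N2C/C(=C\c3cccnc3)C(=O)/C(=C/c3ccccc3F)C2)cc1`: 15800 nM
- compound 2 `Cc1ccc(S(=O)(=O)N2C/C(=C\c3ccncc3)C(=O)/C(=C/c3ccccc3F)C2)cc1`: > 20000 nM (a limit)
- compound 3 `O=C1/C(=C/c2ccncc2)CN(S(=O)(=O)c2ccc(Br)cc2)C/C1=C\c1ccccc1F`: 11500 nM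

Compound 3, at 11500 nM, sits within the usual scatter of compound 1, at 15800 nM. Compound 2 is reported only as a limit, > 20000 nM.

Compound 4 `N#Cc1ccc(S(=O)(=O)N2C/C(=C\c3ccncc3)C(=O)/C(=C/c3ccccc3F)C2)cc1` differs from compound 3 by one change: cyano in place of bromo on an aromatic carbon. Within the data shown here, the only measured step at this place is an at least 1.7-fold lower number from compound 2 to compound 3 (0.24 log units; that floor lies within the scatter), and it involves bromo and methyl, not cyano. Compound 1 also carries the 4-cyanophenyl group and gives 15800 nM. No step beyond the scatter is therefore expected in this assay. The expected size is a 1.1-fold higher number from compound 3 to compound 4 (0.05 log units; within the scatter). Compound 4 is estimated at 13000 nM, with an expected range of 7000 nM to 20000 nM.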

Compound 4, half-maximal inhibitory concentration: 8500 nM
Beside the measured number, compound 4's estimate is 1.5-fold (0.18 log units) above it; low and high end bracket the measured number.
By their numbers in this assay, from the lowest: compounds 4, 3 and 1 (each within the scatter of the next). At a limit, above all of these: compound 2.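

In this assay, among these compounds, cyano on the sulfonyl ring gives the only step at this position beyond the scatter, an at least 2.3-fold lower number from compound 2 to compound 4 (0.37 log units; beyond the scatter). That step starts from compound 2, whose value is a limit and not a number: the limit of > 20000 nM in this assay, at which 1 of the 4 values shown sits.
Replacing bromo with cyano, a 1.4-fold lower number from compound 3 to compound 4 (0.13 log units; within the scatter), and changing pyridin-3-yl to pyridin-4-yl, a 1.9-fold lower number from compound 1 to compound 4 (0.27 log units; within the scatter), both stay within the scatter, so neither change separates these compounds. The compounds shown leave open how an amine or a carboxylic acid at this position would read, and whether any group here would give a clearly lower number than cyano or bromo.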